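Notes on the carboxylic acid amides of the series

The source may hold more compounds than are shown below. What is called first, only, known or untested is meant among the compounds shown, and "the series" means these compounds.

Measured in a functional assay on PC-3 cells (Homo sapiens) for antiproliferative activity, read by MTT assay, with a stated time of 24 h; on this read-out lower numbers stand for stronger inhibition and higher numbers for weaker inhibition:
- compound 1 `CCn1c(C(=O)N[C@@H](C)CO)ccc1C(CC)(CC)c1ccc(OCS(=O)(=O)c2ccccc2)c(C)c1` gives 9520 nM
- compound 2 `CCn1c(C(=O)N[C@H](CO)CCO)ccc1C(CC)(CC)c1ccc(OCS(=O)(=O)c2ccccc2)c(C)c1` gives 12100 nM
- compound 3 `CCn1c(C(=O)NCC(=O)O)ccc1C(CC)(CC)c1ccc(OCS(=O)(=O)c2ccccc2)c(C)c1` gives 30100 nM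

Compound 3 has the highest number of the three. The next structure is compound 4 `CCn1c(C(=O)NC2(C(=O)O)CC2)ccc1C(CC)(CC)c1ccc(OCS(=O)(=O)c2ccccc2)c(C)c1`, with 1-carboxycyclopropyl in place of carboxymethyl on an amide-type nitrogen. Within the data shown here, no measured step makes this exact change. The closest evidence is a 1.3-fold higher number from compound 1 to compound 2 (0.10 log units; within the scatter), an added hydroxymethyl on a saturated chain carbon. The steps of a 3.2-fold higher number from compound 1 to compound 3 (0.50 log units; beyond the scatter) and a 2.5-fold higher number from compound 2 to compound 3 (0.40 log units; beyond the scatter) are modest, and both swap the whole group for carboxymethyl. A step beyond the scatter in this assay is therefore not expected. The expected step is a 1.2-fold lower number from compound 3 to compound 4 (0.08 log units; within the scatter). The estimate for compound 4 is 25000 nM, with an expected range of 12000 nM to 50000 nM.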

Compound 4, half-maximal inhibitory concentration: 26300 nM
Compound 4: middle estimate off by 1.1-fold (0.02 log units), on the low side; measured number inside the range.
By their numbers in this assay, from the lowest: compounds 1 and 2 (each within the scatter of the next); then compounds 4 and 3 (each within the scatter of the next).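

In this assay, 1-carboxycyclopropyl in place of carboxymethyl on the amide-type nitrogen gives a 1.1-fold lower number from compound 3 to compound 4 (0.06 log units; within the scatter) and so adds a three-membered ring of carbon only with no step beyond the scatter. The distance of the carboxylic acids from the hydroxyl-bearing amides also holds for the new ring, with a 2.2-fold higher number from compound 2 to compound 4 (0.34 log units; beyond the scatter) and a 2.8-fold higher number from compound 1 to compound 4 (0.44 log units; beyond the scatter) as the two steps. No measurement on hand explains these steps.

Left open are a methyl ester or a primary amide in place of the carboxylic acid, and a larger ring as in 1-carboxycyclobutyl on the same nitrogen.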